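Removing the phenyl ring: what to expect for compound 3

The source may hold more compounds than are shown below. What is called first, only, known or untested is meant among the compounds shown, and "the series" means these compounds.

compound 1, `N=C(CSCc1ccccc1)NC[C@@H]1C[C@H]2CC[C@H]1C2`: 83%
compound 2, `CC(C)(C)CNC(=N)CCCS`: 11%

In a functional assay on the whole organism (stomach, strain beagle) for inhibition, with Canis familiaris (Canis lupus familiaris) as the target, with a stated time of 2 h, at a dose of 8 mg/kg (on this read-out lower numbers stand for a weaker effect and higher numbers for a stronger effect at the one dose given), compound 1 gives 83%, the highest of the two numbers shown. Compound 2 gives 11%, a gap beyond the scatter; the two structures differ in many places, so this pair teaches little about any single change. Compound 3 `CSCC(=N)NC[C@@H]1C[C@H]2CC[C@H]1C2` differs from compound 1 in one place: hydrogen in place of phenyl on a saturated chain carbon bound to a sulfur. Among the compounds with values here, no measured pair shows this change. A loss of moderate size, beyond the scatter, is the expected step of a number 33 percentage points lower from compound 1 to compound 3 (beyond the scatter). Compound 3 is therefore estimated to give 50%, with a range from 20% to 80%.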

Compound 3, a percentage reported as inhibition, in the whole organism at one dose (the size of the read-out at that dose, not a potency): 35%
The estimate for compound 3 lay 15 percentage points above the measured number; low and high end bracket the measured number.
By their numbers in this assay, from the lowest: compound 2; then compound 3; then compound 1.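

Swapping the phenyl for hydrogen on this saturated chain carbon bound to a sulfur gives a single-change comparison, which the earlier pair could not offer: in this assay the swap brings a number 48 percentage points lower from compound 1 to compound 3 (beyond the scatter), a large loss. The read-out at this dose therefore depends strongly on what sits at this place. No measurement here accounts for the size of this loss. Going by these compounds, whether a methyl group, a cyclohexyl ring or a pyridine ring at this place would restore the read-out remains open.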